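The source may hold more compounds than are shown below. What is called first, only, known or untested is meant among the compounds shown, and "the series" means these compounds.

Compound 1 `CN(C)C(=O)c1cc(-c2cc(F)c(Cl)cc2Cl)n[nH]1` gives 324 nM in an assay on isolated protein for inhibition of alkaline phosphatase, tissue-nonspecific isozyme (Homo sapiens) (on this read-out higher numbers stand for weaker inhibition and lower numbers for stronger inhibition), the higher of the two numbers in hand, while compound 2 `COCCNC(=O)c1cc(-c2ccc(Cl)cc2Cl)n[nH]1` gives 46 nM in this assay. Compound 3 `O=C(c1cc(-c2cc(F)c(Cl)cc2Cl)n[nH]1)N(CCO)CCO` differs from compound 1 in a single place: bis(2-hydroxyethyl)amino in place of dimethylamino on a carbonyl carbon. For the measured compounds named here, no measured pair shows this change by itself, so nothing in hand sets its size. For compound 3 a step of no more than the usual scatter, in either direction, is expected, a 1.3-fold lower number from compound 1 to compound 3 (0.11 log units; within the scatter). On that basis compound 3 is estimated at 250 nM, within a range from 80 nM to 800 nM.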

Compound 3, half-maximal inhibitory concentration: 127 nM
Compound 3: middle estimate off by 2.0-fold (0.29 log units), on the high side, and the stated range covers the measured number.
By their numbers in this assay, from the lowest: compound 2; then compound 3; then compound 1.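

On the carbonyl carbon, bis(2-hydroxyethyl)amino in place of dimethylamino gives a 2.6-fold lower number from compound 1 to compound 3 (0.41 log units; beyond the scatter) in this assay. This place therefore accepts the larger group, and the change brings a modest gain in inhibition. Nothing in hand bears on why the number falls.

From the compounds shown here alone, it remains open whether the hydroxy ends or the chains themselves carry the gain, which diethylamino or bis(2-methoxyethyl)amino on the same carbonyl carbon could separate. Going by these compounds, whether the step holds on the aryl pattern of compound 2 also remains open.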